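A methoxyphenyl for a pyridyl ring at the far end

The compounds below may be only part of what the source reports. "The series", "measured", "known", "first", "only" and "open" are said of these compounds alone.

Compounds measured so far:
compound 1 `CC[C@H](C)[C@H](N)CN(C(=O)[C@@H]1C[C@H]1c1nccs1)c1ccc(-c2ccccc2)cc1` gives 210 nM
compound 2 `CC[C@H](C)[C@H](N)CN(C(=O)[C@@H]1C[C@H]1c1cccs1)c1ccc(-c2ccccc2)cc1` gives 360 nM
compound 3 `CC(C)C[C@H](N)CN(C(=O)[C@@H]1C[C@H]1c1ccccc1)c1ccc(-c2ccncc2)cc1` gives 13000 nM

These values come from a functional assay for agonist activity at G protein-coupled receptor 88 (Homo sapiens), read by HTRF and cAMP accumulation; on this read-out lower numbers stand for an effect already at smaller amounts and higher numbers for an effect only at larger amounts of compound. Compound 3 has the highest number of the three; its nearest neighbour, compound 2, sits well beyond the scatter below it. Compound 4 `COc1ccc(-c2ccc(N(C[C@@H](N)CC(C)C)C(=O)[C@@H]3C[C@H]3c3ccccc3)cc2)cc1` differs from compound 3 in one place: 4-methoxyphenyl in place of pyridin-4-yl on an aromatic carbon. Among the measured compounds shown here, the only single-place step measured, a 1.7-fold higher number from compound 1 to compound 2 (0.23 log units; within the scatter), concerns a different part of the molecule and says nothing about this exchange. Compounds 1 and 2, which carry a phenyl rather than a pyridyl ring, differ from compound 3 in more than one place, so their values merely hint that a carbon-only ring goes with a lower number. Compound 4 is therefore expected to fall by an 8.7-fold lower number from compound 3 to compound 4 (0.94 log units; beyond the scatter), with an estimated 1500 nM (range 300 nM to 8000 nM).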

Compound 4, half-maximal effective concentration: 330 nM
Beside the measured number, compound 4's estimate is 4.5-fold (0.66 log units) above it, and the stated range covers the measured number.
By their numbers in this assay, from the lowest: compounds 1, 4 and 2 (each within the scatter of the next); then compound 3.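

In this assay the exchange of pyridin-4-yl for 4-methoxyphenyl (a 39-fold lower number from compound 3 to compound 4 (1.60 log units; beyond the scatter)) is a large step, beyond the scatter. Among the compounds shown here, this is the first single-place evidence that the group on this aromatic carbon, para to a large group, strongly affects the number, whereas the only earlier step, at a different place, stayed within the scatter. No measurement here explains why the number drops so far. As far as these compounds go, the exchange removes the ring nitrogen and adds the methoxy group together, so which of these matters remains open. Also open, from the compounds shown here alone, is how a hydroxyl or a chlorine in place of the methoxy group would read.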